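This account rests on a few compounds, and the source may have more. Where it says the series, first, only, none or still open, it means among the compounds named here.

Measured so far:
- compound 1, `COc1ccc(-c2cc(/C=C/C(=O)c3ccc(N)cc3)[nH]n2)cc1`: 7490 nM
- compound 2, `COc1cc(-c2cc(/C=C/C(=O)c3ccc(N)cc3)[nH]n2)cc(OC)c1OC`: 3920 nM

In a functional assay on HOP-62 cells (Homo sapiens) for inhibition, read by sulforhodamine B assay, with a stated time of 48 h (on this read-out higher numbers stand for weaker inhibition of growth and lower numbers for stronger inhibition of growth), compound 1 gives 7490 nM and compound 2 gives 3920 nM. Compound 2 has the smaller of the two numbers, but the gap to compound 1 is within the scatter, so the two are not separated. Compound 3, `COc1cc(-c2cc(/C=C/C(=O)c3ccc(F)c(F)c3)[nH]n2)cc(OC)c1OC`, is not yet measured. It differs from compound 2 by 3,4-difluorophenyl in place of 4-aminophenyl on a carbonyl carbon. Within the data shown here, no measured pair shows this change, so nothing indicates a step beyond the scatter in either direction. Compound 3 is therefore expected near compound 2, with a 1.1-fold higher number from compound 2 to compound 3 (0.06 log units; within the scatter), at an estimated 4500 nM with a range of 1500 nM to 14000 nM.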

Compound 3, concentration for total growth inhibition: > 100000 nM
Compound 3 was reported as a limit; the forecaster's own chance of this, stated with the estimate: 5%; middle value at least 22-fold (1.34 log units) from the limit.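

Among these compounds, compound 1 and compound 2 both carry 4-aminophenyl on the carbonyl carbon, so this place had not yet been varied. It proves sensitive in this assay: 3,4-difluorophenyl in place of 4-aminophenyl gives an at least 25-fold higher number from compound 2 to compound 3 (1.40 log units; beyond the scatter). The value for compound 3 is a limit and not a number: the limit of > 100000 nM in this assay, at which 1 of the 3 values shown sits.

The compounds shown leave open whether the step follows the departure of the amine or the arrival of the two fluorines. Plain phenyl or 4-hydroxyphenyl on the same carbonyl carbon would separate these two readings.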